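One added methyl on the lower-clearance compound

This account rests on a few compounds, and the source may have more. Where it says the series, first, only, none or still open, it means among the compounds named here.

In an ADME assay on the whole organism for pharmacokinetics, with Rattus norvegicus as the target (a lower number here means slower removal, a higher number faster removal of the compound), compound 1 `COCC[C@H](Oc1ncnc2c1cnn2-c1ccccc1Cl)C(=O)Nc1ccc(C)cn1` gives 37 mL/min/kg and compound 2 `COC[C@H](Oc1ncnc2c1cnn2-c1ncccc1Cl)C(=O)Nc1cnc(C)cn1` gives 4 mL/min/kg as the lower of the two numbers, a gap beyond the scatter. Compound 3 `CCOC[C@H](Oc1ncnc2c1cnn2-c1ncccc1Cl)C(=O)Nc1cnc(C)cn1` differs from compound 2 by methyl in place of hydrogen on a saturated chain carbon bound to an oxygen on a saturated carbon in the change of methoxymethyl to ethoxymethyl. Among the compounds with values here, no measured pair shows this change alone, so only a small rise, within the scatter, is expected. The estimated move is a 1.8-fold higher number from compound 2 to compound 3 (0.24 log units; within the scatter) in this assay on this reasoning. For compound 3 the estimate is 7 mL/min/kg with a range from 3 mL/min/kg to 18 mL/min/kg as the expected bounds.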

Compound 3, clearance in the Rattus norvegicus assay: 50 mL/min/kg
Estimate against measurement, compound 3: 7.1-fold (0.85 log units) below; the whole stated range lies below it.
By their numbers in the Rattus norvegicus assay, from the lowest: compound 2; then compounds 1 and 3 (each within the scatter of the next).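

At this position the chain end is far from neutral: in the Rattus norvegicus assay, methoxymethyl to ethoxymethyl gives a 13-fold higher number from compound 2 to compound 3 (1.10 log units; beyond the scatter), so a single added methyl is enough to lose the low number of compound 2. In a physicochemical assay for lipophilicity (a lower number here means a more polar compound, a higher number a more lipophilic compound), compound 2 gives 1.4 and compound 3 gives 1.8, so the same change also raises the number: the measured distribution coefficient of compound 2, 1.4, and of compound 3, 1.8, a number 0.40 log units higher (beyond the scatter)

This one pair cannot tell whether the two shifts are linked. It also leaves open how a hydroxymethyl group or a longer chain such as propoxymethyl would read in the Rattus norvegicus assay at this position.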